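Naphthalen-2-yl for 4-methoxyphenyl: a second pairing

The source may hold more compounds than are shown below. What is called first, only, known or untested is meant among the compounds shown, and "the series" means these compounds.

Measured so far, in a functional assay on MDA-MB-231 cells (Homo sapiens) for cytotoxicity, read by MTT assay, with a stated time of 72 h; a lower number here means a stronger inhibitor, a higher number a weaker inhibitor:
compound 1 `COc1ccc(/C=C2\S/C(=N\c3csc(-c4ccc(Cl)cc4)c3)NC2=O)cc1`: 1200 nM
compound 2 `O=C1N/C(=N/c2csc(-c3ccc(Cl)cc3)c2)S/C1=C\c1ccc2ccccc2c1`: 1800 nM
compound 3 `COc1ccc(/C=C2\S/C(=N\c3nc(-c4ccc(Cl)cc4)cs3)NC2=O)cc1`: 300 nM

Compound 1 and compound 2 share a core and differ only in one group, (naphthalen-2-yl in place of 4-methoxyphenyl on a double-bonded chain carbon bound to a double-bonded ring carbon). The step of a 1.5-fold higher number from compound 1 to compound 2 (0.18 log units; within the scatter) is within the scatter, so the two values are read as equivalent in this assay.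

Compound 3 carries the 4-methoxyphenyl group of compound 1 on a different core; the difference between the two cores is not broken down here. Compound 3 has the lowest number of the three, and its gap to compound 1 is beyond the scatter.

Compound 4 `O=C1N/C(=N/c2nc(-c3ccc(Cl)cc3)cs2)S/C1=C\c1ccc2ccccc2c1` is not yet measured. It relates to compound 3 as compound 2 relates to compound 1, by the same change at the same place, (naphthalen-2-yl in place of 4-methoxyphenyl on a double-bonded chain carbon bound to a double-bonded ring carbon). The expected step of a 1.5-fold higher number from compound 3 to compound 4 (0.18 log units; within the scatter) rests on the single earlier pairing, where the step of a 1.5-fold higher number from compound 1 to compound 2 (0.18 log units; within the scatter) stayed within the scatter. The estimate for compound 4 is therefore 450 nM in this assay, with a range from 200 nM to 1100 nM.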

Compound 4, half-maximal inhibitory concentration: 900 nM
Compound 4: middle estimate off by 2.0-fold (0.30 log units), on the low side, and the stated range covers the measured number.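

In this assay, naphthalen-2-yl in place of 4-methoxyphenyl gives a 3.0-fold higher number from compound 3 to compound 4 (0.48 log units; beyond the scatter). That step lies beyond the scatter while the earlier one on the core of compound 1 does not, yet the two steps cannot be told apart: the same change on two cores in this assay, a 1.5-fold higher number (0.18 log units; within the scatter) from compound 1 to compound 2 and a 3.0-fold higher number (0.48 log units; beyond the scatter) from compound 3 to compound 4, 2.0-fold (0.30 log units) apart, within the scatter of two such steps. Within the data shown here, the change can therefore be carried between these two cores as a step of similar size, but this rests on only two pairs in a single assay and does not show that it would hold on any other core, or why either step has the size it has.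

Open, from the compounds shown here alone, is whether a group such as pyridin-3-yl, 4-(dimethylamino)phenyl or 4-carboxyphenyl, on a double-bonded chain carbon bound to a double-bonded ring carbon, would give steps of similar size on these two cores. Also open, going by these compounds, is whether the two steps would keep their size in cells other than those of this assay.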